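The source may hold more compounds than are shown below. What is called first, only, known or untested is meant among the compounds shown, and "the series" means these compounds.

Of the compounds shown here, three have been tested so far, all sharing one core. Compound 1 `CC(=O)N1CCc2cc(CNC(=O)c3cccs3)ccc21` gives 72% in an assay on HEK293 cells for inhibition of Indoleamine 2,3-dioxygenase 1 (Homo sapiens), tested at 10 uM; on this read-out higher numbers stand for more inhibition at the one concentration tested (going by the name of the read-out) and lower numbers for less inhibition. Compound 2 `CC(C)CC(=O)N1CCc2cc(CNC(=O)C3CC3)ccc21` gives 35% in this assay. Compound 3 `CC(C)C(=O)N1CCc2cc(CNC(=O)c3ccc(F)cc3)ccc21` gives 88% in this assay, the highest of the three numbers: compound 1 sits closest, a number beyond the usual scatter below it, and compound 2 sits farthest, a number well beyond the scatter below it.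

Compound 4 `CC(C)C(=O)N1CCc2cc(CNC(=O)c3cccs3)ccc21` is the next compound, not yet measured, and it differs from compound 3 in one place: thiophen-2-yl in place of 4-fluorophenyl on a carbonyl carbon. Compound 1 carries the same thiophen-2-yl group on its carbonyl carbon, though it differs from compound 4 elsewhere, so its value gives some guide to what this change may do. In this assay compound 1 gives 72%, which sits below compound 3 by a margin beyond the scatter.

On that basis a small downward step is expected for compound 4, close to the edge of the scatter, because compound 1 gives 72% while compound 3 gives 88%. The expected step from compound 3 to compound 4 in this assay is a number 12 percentage points lower from compound 3 to compound 4 (beyond the scatter). Compound 4 is therefore estimated to reach about 76% in this assay, most likely between 58% and 90%.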

Compound 4, a percentage reported as inhibition, at one concentration (the size of the read-out at that concentration, not a potency): 100%
For compound 4 the middle estimate is 24 percentage points below the measured one; the measured number lies above the stated range.
By their numbers in this assay, from the lowest: compound 2; then compound 1; then compound 3; then compound 4.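

Once only one place changes, the effect of each group can be read on its own, which the first three compounds did not allow. In this assay, putting thiophen-2-yl in place of 4-fluorophenyl on the carbonyl carbon gives a number 12 percentage points higher from compound 3 to compound 4 (beyond the scatter), so on this shared core with its isopropyl group, the number is higher with the five-membered ring with one sulfur atom than with the fluorinated six-membered ring. Isopropyl in place of methyl on the other carbonyl carbon gives a number 28 percentage points higher from compound 1 to compound 4 (beyond the scatter), which shows that this second position also affects the read-out, although no measurement here explains either step.

The thiophen-2-yl swap changes ring size and hetero atom together, so furan-2-yl, with its oxygen in a five-membered ring, or plain phenyl, would be needed to tell those two changes apart. As far as these compounds go, it also remains open how a tert-butyl or a propyl group would behave in place of isopropyl, and how compound 4 would rank against close relatives in a full potency measurement, since this assay reports inhibition at one concentration only.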